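The source may hold more compounds than are shown below. What is called first, only, known or untested is meant among the compounds shown, and "the series" means these compounds.

Measured so far in a functional assay on NIH3T3 cells (Mus musculus); on this read-out lower numbers stand for an effect already at smaller amounts and higher numbers for an effect only at larger amounts of compound:

compound 1 `N#Cc1ccc(Cn2cncc2CNc2ccc(C(=O)NCc3ccccc3)c(-c3ccccc3)c2)cc1` — compound 1 gives > 10 uM, a limit of this assay rather than a number.
compound 2 `N#Cc1ccc(Cn2cncc2CNc2ccc(C(=O)NCC3CCCCC3)c(-c3ccccc3)c2)cc1` — compound 2 gives > 10 uM, again only a limit.

Compound 2 therefore has no fixed place among the numbers: it sits at the limit of this assay, and nothing more is known of it. Among the measured compounds shown here, the only step measured, a step that the two limits leave unreadable from compound 1 to compound 2, stays unreadable, both of its values resting at the limit of > 10 uM in this assay, at which 2 of the 2 values shown sit. Compound 3 `N#Cc1ccc(Cn2cncc2CNc2ccc(C(=O)Nc3cccc(C#N)c3)c(-c3ccccc3)c2)cc1` differs from compound 2 by 3-cyanophenyl in place of cyclohexylmethyl on an amide-type nitrogen. For the measured compounds named here, no measured step bears on an aromatic group at this amide nitrogen, so the series offers no direction for this change beyond the scatter; two limits give no anchor. In this assay compound 3 is expected to give about 15 uM, with a range from 4 uM to 60 uM. That estimate amounts to an expected step that the limit leaves unreadable from compound 2 to compound 3, most likely again reported only as a limit.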

Compound 3, concentration for half-maximal effect: > 10 uM
Compound 3: only a limit was reported (the forecaster's own chance of this, stated with the estimate: 70%); the middle value lies beyond the limit too.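

Compound 3 joins compound 1 and compound 2 at a limit of the assay, so no step among these three compounds can be read: the limit of > 10 uM in this assay, at which 3 of the 3 values shown sit.

Still open, going by these compounds, is whether any group on the amide-type nitrogen of the shared core gives a measured value rather than a limit.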